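Removing One Methoxy Group from a Sulfonamide Amine

A few compounds are considered here, and "the series" means these few. Any claim that something is new, unique, unknown or untested is made for them only; others in the source may bear on it.

Of the compounds shown here, three have been measured so far. Compound 1 `COc1ccc(CNCCCNS(=O)(=O)c2cc(C(F)(F)F)cc(C(F)(F)F)c2)cc1OC` stands lowest of the three: in a functional assay on MIA PaCa-2 cells (Homo sapiens) for inhibition, read by MTT assay, with a stated time of 72 h (on this read-out lower numbers stand for stronger inhibition of growth and higher numbers for weaker inhibition of growth), compound 1 gives 2800 nM. Compound 2 `CC(C)c1ccc(S(=O)(=O)NCCCCCCNCc2ccc(Br)cc2)cc1` gives 5730 nM, and compound 3 `O=[N+]([O-])c1ccc(S(=O)(=O)NCCCCCCNCc2ccc(Br)cc2)cc1` gives 9800 nM, so compound 1 sits beyond the scatter from both. Going by the values given here, the only measured step between neighbours, a 1.7-fold higher number from compound 2 to compound 3 (0.23 log units; within the scatter), concerns a group at the far end of a different pair and does not reach past the scatter. Compound 4 `COc1ccc(CNCCCNS(=O)(=O)c2cc(C(F)(F)F)cc(C(F)(F)F)c2)cc1` differs from compound 1 by a single change: hydrogen in place of methoxy on an aromatic carbon. Among the compounds with values here, no measured step touches this part of the molecule, so there is no direct guide for its size or direction, and a small change of this kind would be expected to stay within the scatter or to weaken inhibition only slightly. The step of a 1.3-fold higher number from compound 1 to compound 4 (0.10 log units; within the scatter) is therefore the expectation. For compound 4 an estimate of 3500 nM is expected, with a range from 1500 nM to 8500 nM.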

Compound 4, concentration for 50% growth inhibition: 2500 nM
Compound 4: the middle estimate sits 1.4-fold (0.15 log units) above what was measured; the range from low to high includes it.
By their numbers in this assay, from the lowest: compounds 4 and 1 (each within the scatter of the next); then compounds 2 and 3 (each within the scatter of the next).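

With hydrogen in place of methoxy, this position, ortho to a methoxy group, gives a 1.1-fold lower number from compound 1 to compound 4 (0.05 log units; within the scatter) in this assay, so the second methoxy group can be lost without a change beyond the scatter. On this read-out, the 3,4-dimethoxybenzyl and 4-methoxybenzyl groups cannot be told apart, something the earlier step could not show, as it swapped isopropyl for nitro in a different pair. Nothing available here explains this result.

Still open, on these data alone, is whether another replacement at this position, such as a fluorine atom, a hydroxyl group or an ethoxy group, would also stay within the scatter. Also open, as far as these compounds go, is whether the remaining methoxy group could go too, leaving a plain benzyl group.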